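A few compounds are considered here, and "the series" means these few. Any claim that something is new, unique, unknown or untested is made for them only; others in the source may bear on it.

Compound 1 `CN1CCN(S(=O)(=O)c2c(Cl)ccc(NC(=O)Nc3cccc(Cl)c3Cl)c2O)CC1` and compound 2 `O=C(Nc1ccc(Cl)c(C(=O)N2CCCCC2)c1O)Nc1cccc(F)c1Cl` were both followed in an ADME assay on the whole organism (blood, Mus musculus, strain C57BL/6) for pharmacokinetics, read by HPLC, with a stated time of 4 h, at a dose of 2 mg/kg by the intraperitoneal route; a lower number here means less compound in the circulation, a higher number more compound in the circulation at the dose given. In this assay compound 1 gives 303 ng.h/mL. For compound 2 the picture is different: in this assay compound 2 is recorded as "below limit of detection" (no number reported), so compound 2 has no single value to stand on here. Compound 3 `O=C(Nc1ccc(Cl)c(C(=O)N2CCCC2)c1O)Nc1cccc(F)c1Cl` has not yet been measured. It differs from compound 2 in one place: pyrrolidin-1-yl in place of piperidin-1-yl on a carbonyl carbon. Going by the values given here, no measured pair in this set shows a step of this kind, so nothing here says how large a change to expect from it. The expectation is therefore a step in this assay of no more than the usual scatter, in either direction, with the outcome for compound 2 as the only anchor. On that basis compound 3 is expected to give about 20 ng.h/mL in this assay, within a range from 5 ng.h/mL to 100 ng.h/mL, and with a real chance that the assay again reports no number.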

Compound 3, area under the concentration-time curve: "below limit of detection" (no number reported)
For compound 3 the study gives words and no number; the estimate stays without a comparison.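

In this assay compound 2 and compound 3 are both recorded in words without a number, so no step can be read for the change from piperidin-1-yl to pyrrolidin-1-yl. No supporting measurement bears on this result. The compounds shown leave open how much either group, on the shared core, alters the amount of compound in the circulation.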